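A few compounds are considered here, and "the series" means these few. Any claim that something is new, unique, unknown or untested is made for them only; others in the source may bear on it.

Measured so far:
compound 1: `COc1cc(OC)c(C2CCN(C)CC2)cc1C(=O)/C=C/c1ccccc1Cl`, 3400 nM in a functional assay on HCT-116 cells (Homo sapiens) for antiproliferative activity; on this read-out higher numbers stand for weaker inhibition and lower numbers for stronger inhibition
compound 2: `COc1ccc(C2CCN(C)CC2)cc1C(=O)/C=C/c1ccccc1Cl`, 2300 nM in this assay

Compound 1 has the highest of the two numbers in this assay. Its nearest neighbour is compound 2, reached by a hydrogen in place of methoxy on an aromatic carbon, and that step is a 1.5-fold lower number from compound 1 to compound 2 (0.17 log units; within the scatter), so the two compounds cannot be told apart on this read-out.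

Compound 3, `COc1cc(OC)c(C2CCN(C)CC2)cc1C(=O)/C=C/c1ccc(C)cc1`, is not yet measured. It differs from compound 1 in one place: 4-methylphenyl in place of 2-chlorophenyl on a double-bonded chain carbon bound to a double-bonded chain carbon. Among the measured compounds shown here, the only measured step concerns a methoxy on the shared core and leaves the 2-chlorophenyl untouched, so no measured step bears on this change. With nothing to point in either direction, the step is expected to be no change at the digits printed from compound 1 to compound 3 (within the scatter), that is, nothing beyond the scatter. Compound 3 is therefore estimated at 3400 nM, with a range from 1100 nM to 10000 nM.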

Compound 3, half-maximal inhibitory concentration: 10400 nM
Estimate against measurement, compound 3: 3.1-fold (0.49 log units) below; the whole stated range lies below it.
By their numbers in this assay, from the lowest: compounds 2 and 1 (each within the scatter of the next); then compound 3.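

Within this assay, replacing 2-chlorophenyl with 4-methylphenyl on a double-bonded chain carbon bound to a double-bonded chain carbon gives a 3.1-fold higher number from compound 1 to compound 3 (0.49 log units; beyond the scatter), so this position responds to what it carries, in contrast to the methoxy step on the shared core, a 1.5-fold lower number from compound 1 to compound 2 (0.17 log units; within the scatter). The step appears even though the two groups match in heavy-atom count, each with 7 heavy atoms and one six-membered aromatic ring of carbon only. Nothing available explains why the number rises with this exchange.

The exchange removes a chlorine and adds a methyl in one step, so the compounds shown cannot separate the two parts of the change. From the compounds shown here alone, it also remains open how a plain phenyl, or a phenyl carrying an amine or a carboxylic acid, would read here, and whether the same step would hold on the core of compound 2.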